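Replacing the Amide Nitrogen with an Acyl Azo Group

The compounds below may be only part of what the source reports. "The series", "measured", "known", "first", "only" and "open" are said of these compounds alone.

Of the compounds shown here, two have been measured in a physicochemical assay for lipophilicity; a higher number here means a more lipophilic compound, a lower number a more polar compound. Compound 1, `CN(C)/N=N/c1ccccc1C(=O)/N=N/C(=O)CC#N`, gives 1.44, and compound 2, `CN(C)/N=N/c1ccccc1C(N)=O`, gives 1.73. Compound 2 holds the higher of the two numbers, but its distance to compound 1 lies within the scatter of the measurement, so the two cannot be told apart on this evidence.

The step to compound 3, `CC(=O)/N=N/C(=O)c1ccccc1/N=N/N(C)C`, changes compound 2 in one place: a group of 5 heavy atoms (2 carbon, 2 nitrogen, 1 oxygen; no ring) in place of one nitrogen atom, on a carbonyl carbon. Among the compounds with values here, no measured pair shows a change of this kind, so the size of the step is open. Compound 1 carries a related group and gives 1.44, which suggests the new group need not move the number far. For compound 3 the expected step is a number 0.07 log units higher from compound 2 to compound 3 (within the scatter), not clearly beyond the scatter in either direction. Compound 3 is estimated at 1.8, within a range from 1.3 to 2.4.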

Compound 3, partition coefficient: 1.49
Compound 3: the middle estimate sits 0.31 log units above what was measured, and the stated range covers the measured number.
By their numbers in this assay, from the lowest: compounds 1, 3 and 2 (each within the scatter of the next).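

In this assay, putting a group of 5 heavy atoms in place of the amino group on a carbonyl carbon gives a number 0.24 log units lower from compound 2 to compound 3 (within the scatter) and so does not separate the two compounds, even though the amide hydrogens are gone and the group is much larger. Hydrogen in place of cyano on the saturated chain carbon gives a number 0.05 log units higher from compound 1 to compound 3 (within the scatter) and likewise leaves compound 1 and compound 3 indistinguishable, so this group tolerates both changes without a readable shift on this evidence. No supporting information explains why these steps are small.

On these data alone, whether a carboxylic acid or a longer chain in this group would produce a step beyond the scatter remains open. It is also unknown how an amine on the saturated chain carbon would compare with hydrogen or cyano there.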